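Removing the ring benzyl from a cytotoxic sulfonamide

A few compounds are considered here, and "the series" means these few. Any claim that something is new, unique, unknown or untested is made for them only; others in the source may bear on it.

Measured compounds:
- compound 1, `CC(=O)OCCOCN1C(=O)c2ccccc2NS1(=O)=O`: > 200 ug/mL
- compound 2, `O=C1NS(=O)(=O)N(COCc2ccccc2)c2ccccc21`: > 200 ug/mL
- compound 3, `O=C1c2ccccc2N(Cc2ccccc2)S(=O)(=O)N1COCc1ccccc1`: 100 ug/mL

In a functional assay on CCRF-CEM cells (Homo sapiens) for cytotoxicity (on this read-out lower numbers stand for higher toxicity in this test and higher numbers for lower toxicity in this test), compound 1 reaches only a limit of the test, > 200 ug/mL. Compound 2 likewise gives only a limit in this assay, > 200 ug/mL. Going by the values given here, compound 3 is the one compound with a number in this assay, 100 ug/mL. Compound 1 and compound 2 sit at a limit (the limit of > 200 ug/mL in this assay, at which 2 of the 3 values shown sit).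

The step from compound 3 to compound 4, `O=C1c2ccccc2NS(=O)(=O)N1COCc1ccccc1`, is hydrogen in place of benzyl on a sulfonamide nitrogen in a ring. Among the compounds with values here, no measured pair shows this change, so its size in this assay is not known from the data.

Compound 4 is expected to be less toxic than compound 3 in this assay, with the estimated step of a 2.0-fold higher number from compound 3 to compound 4 (0.30 log units; within the scatter). The estimate for compound 4 in this assay is 200 ug/mL, within a range from 100 ug/mL to 400 ug/mL, and it may well come back as a limit of the test rather than a number.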

Compound 4, half-maximal cytotoxic concentration: 91 ug/mL
Estimate against measurement, compound 4: 2.2-fold (0.34 log units) above; measured number outside the range, below it.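

In this assay, the sulfonamide nitrogen in the ring carries benzyl or hydrogen without a readable difference, the swap giving a 1.1-fold lower number from compound 3 to compound 4 (0.04 log units; within the scatter), so toxicity in this test does not hang on that benzyl in this pair. The chain at the other end of the molecule now gives a step that can be read, with phenyl in place of acetoxymethyl on a saturated chain carbon bound to an oxygen on a saturated carbon giving an at least 2.1-fold lower number from compound 1 to compound 4 (0.34 log units; beyond the scatter). Compound 1 remains a limit of the test, so that step has no upper size: the limit of > 200 ug/mL in this assay, at which 2 of the 4 values shown sit.

On these data alone, whether a methyl or a longer chain on the sulfonamide nitrogen would read the same as hydrogen and benzyl stays open. So does the effect of an amine or a carboxylic acid in place of the phenyl.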